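Fluoro for methoxy in a series at the limit

The compounds below may be only part of what the source reports. "The series", "measured", "known", "first", "only" and "open" are said of these compounds alone.

In a functional assay on MCF7 cells (Homo sapiens) for antiproliferative activity, read by MTT assay, with a stated time of 48 h (on this read-out lower numbers stand for stronger inhibition and higher numbers for weaker inhibition), compound 1 (`COc1ccc(-c2nc3cccc(-c4cc(OC)c(OC)c(OC)c4)c3o2)cc1`) gives > 25000 nM, which is a limit and not a number. Compound 2 (`COc1cccc(-c2nc3cccc(-c4cc(OC)c(OC)c(OC)c4)c3o2)c1`) gives > 25000 nM, also a limit. Compound 3 (`COc1ccc(-c2nc3cccc(-c4cc(OC)c(OC)c(OC)c4)c3o2)cc1OC`) gives > 25000 nM, again a limit, so it has no number of its own. All three stand at the limit of > 25000 nM in this assay, at which 3 of the 3 values shown sit.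

Compound 4 (`COc1ccc(-c2nc3cccc(-c4cc(OC)c(OC)c(OC)c4)c3o2)cc1F`) carries fluoro in place of methoxy on an aromatic carbon, turning 3,4-dimethoxyphenyl to 3-fluoro-4-methoxyphenyl: fluoro in place of methoxy on an aromatic carbon.

Among the measured compounds shown here, three measured steps bear on this change: a step that the two limits leave unreadable from compound 1 to compound 2, a step that the two limits leave unreadable from compound 1 to compound 3 and a step that the two limits leave unreadable from compound 2 to compound 3. None of them has a size that could be carried over, so no direction can be favoured. What is expected is a step that the limit leaves unreadable from compound 3 to compound 4, with no clear shift beyond the scatter. For compound 4 the estimate is 30000 nM, with an expected range from 12000 nM to 60000 nM, and the assay may well report only a limit again.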

Compound 4, half-maximal inhibitory concentration: > 25000 nM
Compound 4: a limit, no number; the forecaster's own chance of this, stated with the estimate: 75%; the middle value lies beyond the limit too.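

Compound 4 ends at a limit, as compounds 1, 2 and 3 do, so no step among these four compounds can be read, in size or in direction: the limit of > 25000 nM in this assay, at which 4 of the 4 values shown sit.

The compounds shown leave open whether fluoro in place of methoxy changes anything in this assay.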